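Methyl in Place of Trifluoromethyl: Compound 3 to Compound 4

The source may report more compounds than this note shows. Statements on the series, on what has been measured and on what is new or still open speak of the compounds shown alone.

In a functional assay on HL-60 cells (Homo sapiens) for antiproliferative activity, with a stated time of 24 h (on this read-out lower numbers stand for stronger inhibition and higher numbers for weaker inhibition), compound 1 `NC(=O)c1c(NC(=O)c2ccccc2C(F)(F)F)sc2c1CCN(C(=S)Nc1ccccc1Cl)C2` gives 17600 nM.
In this assay compound 2 `Cc1ccccc1C(=O)Nc1sc2c(c1C(N)=O)CCN(C(=S)Nc1ccccc1Cl)C2` gives 20900 nM.
In this assay compound 3 `NC(=O)c1c(NC(=O)c2ccc(C(F)(F)F)cc2)sc2c1CCN(C(=S)Nc1ccccc1Cl)C2` gives 36100 nM.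

Compound 3 holds the highest number of the three: a 2.1-fold higher number from compound 1 to compound 3 (0.31 log units; beyond the scatter), whereas a 1.7-fold higher number from compound 2 to compound 3 (0.24 log units; within the scatter). Compound 4 `Cc1ccc(C(=O)Nc2sc3c(c2C(N)=O)CCN(C(=S)Nc2ccccc2Cl)C3)cc1` differs from compound 3 by methyl in place of trifluoromethyl on an aromatic carbon. For the measured compounds named here, one measured step bears on this exchange, the same swap of methyl for trifluoromethyl on an aromatic carbon: a 1.2-fold higher number from compound 1 to compound 2 (0.07 log units; within the scatter). On that basis compound 4 is expected to sit close to compound 3 in this assay, with an expected step of a 1.1-fold higher number from compound 3 to compound 4 (0.04 log units; within the scatter). The estimate for compound 4 is 40000 nM, within a range from 20000 nM to 80000 nM.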

Compound 4, half-maximal inhibitory concentration: 8430 nM
The estimate for compound 4 lay 4.7-fold (0.68 log units) above the measured number, outside the stated range (below it).
By their numbers in this assay, from the lowest: compound 4; then compounds 1, 2 and 3 (each within the scatter of the next, the first and the last beyond it).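

In this assay, methyl in place of trifluoromethyl para to a large group gives a 4.3-fold lower number from compound 3 to compound 4 (0.63 log units; beyond the scatter), so this exchange matters at this position. The 4-methylphenyl group also sets compound 4 apart from the compounds carrying 2-methylphenyl and 2-(trifluoromethyl)phenyl, with a 2.5-fold lower number from compound 2 to compound 4 (0.39 log units; beyond the scatter) and a 2.1-fold lower number from compound 1 to compound 4 (0.32 log units; beyond the scatter), which makes compound 4 the strongest of the four. The same exchange therefore does not carry over from one setting to the other: the same change on two cores in this assay, a 1.2-fold higher number (0.07 log units; within the scatter) from compound 1 to compound 2 and a 4.3-fold lower number (0.63 log units; beyond the scatter) from compound 3 to compound 4, 5.1-fold (0.71 log units) apart, beyond the scatter of two such steps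

The compounds shown leave open whether an ethyl chain, a methoxy group or an amine in the same place would keep the low number of compound 4.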